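A few compounds are considered here, and "the series" means these few. Any claim that something is new, unique, unknown or untested is made for them only; others in the source may bear on it.

In a functional assay on Huh-7 cells (Homo sapiens) for cytotoxicity, read by MTT assay, with a stated time of 3 days (a lower number here means that less compound is tolerated, a higher number that more compound is tolerated), three compounds that share one core have been tested, and none has given a number. Compound 1 `OC[C@H]1O[C@@H](n2cnc3c(COc4ccccc4)ncnc32)[C@H](O)[C@@H]1O`, with phenoxy on a saturated chain carbon bound to an aromatic carbon, reads > 100000 nM, which is a limit of the assay. Compound 2 `[N-]=[N+]=NCc1ncnc2c1ncn2[C@@H]1O[C@H](CO)[C@@H](O)[C@H]1O`, with azido in that place, reads > 250000 nM, also a limit. Compound 3 `OC[C@H]1O[C@@H](n2cnc3c(Cn4cccn4)ncnc32)[C@H](O)[C@@H]1O`, with 1H-pyrazol-1-yl there, reads > 250000 nM, again a limit and not a number. The record therefore consists of the limit of > 100000 nM in this assay, at which 1 of the 3 values shown sits, together with the limit of > 250000 nM in this assay, at which 2 of the 3 values shown sit.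

Compound 4 `O=C(O)CSCc1ncnc2c1ncn2[C@@H]1O[C@H](CO)[C@@H](O)[C@H]1O` has (carboxymethyl)sulfanyl in place of 1H-pyrazol-1-yl on a saturated chain carbon bound to an aromatic carbon. The measured steps that bear on this change are swaps at the same place: a step that the two limits leave unreadable from compound 1 to compound 2, a step that the two limits leave unreadable from compound 1 to compound 3 and a step that the two limits leave unreadable from compound 2 to compound 3. None of them has a readable size, so they offer no measured effect of a swap here. Resting on compound 3 and on a step that the two limits leave unreadable from compound 2 to compound 3, no step beyond the scatter is expected in this assay, and no direction can be given. The expected step is a number no higher from compound 3 to compound 4 (the limit leaves the size open). For compound 4 the estimate is 250000 nM, with an expected range from 100000 nM to 500000 nM.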

Compound 4, half-maximal cytotoxic concentration: > 100000 nM
Compound 4: only a limit was reported; the forecaster's own chance of this, stated with the estimate: 85%; the middle value lies beyond the limit too.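

In this assay, compound 4 reads > 100000 nM, which is a limit of the assay and not a number. The steps to compound 4 from compound 1, compound 2 and compound 3 cannot be read, as all four values are limits. The compounds shown leave open whether any swap on the saturated chain carbon changes the tolerated concentration at all.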